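Ethoxycarbonyl in Place of Methyl on a Urea

A few compounds are considered here, and "the series" means these few. Any claim that something is new, unique, unknown or untested is made for them only; others in the source may bear on it.

Measured so far:
compound 1 `Cc1cccc(NC(=O)N[C@H](C)c2ccccc2)c1` — 98%
compound 2 `Cc1cccc(NC(=O)N[C@@H](C)c2ccccc2)c1` — 100%
compound 3 `C[C@H](NC(=O)Nc1ccc(C(F)(F)F)cc1)c1ccccc1` — 94%

In an ADME assay on the whole organism with Oryza sativa as the target, tested at 1 uM (on this read-out higher numbers stand for a weaker effect at the one concentration tested and lower numbers for a stronger effect), compound 1 stands among three numbers that all lie within the scatter of one another: compound 2 differs by a number 2 percentage points higher from compound 1 to compound 2 (within the scatter), and compound 3 shows a value that is also within the scatter of compound 1. Going by the values given here, the one measured step rests on (the fact that compounds 1 and 2 differ only in the configuration as drawn), a change of configuration alone, and says nothing about swapping one group for another on the ring.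

Compound 4 `CCOC(=O)c1cccc(NC(=O)N[C@H](C)c2ccccc2)c1` differs from compound 1 by ethoxycarbonyl in place of methyl on an aromatic carbon. Among the compounds with values here, no measured step bears on this change, so no shift beyond the scatter is expected, giving an estimated a number 3 percentage points lower from compound 1 to compound 4 (within the scatter). Compound 4 is therefore expected to give about 95%, between 85% and 100%.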

Compound 4, a percentage reported as activity, at one concentration (the size of the read-out at that concentration, not a potency): 94%
The estimate for compound 4 lay 1 percentage points above the measured number; low and high end bracket the measured number.
By their numbers in this assay, from the lowest: compounds 3, 4, 1 and 2 (each within the scatter of the next).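

In this assay, ethoxycarbonyl in place of methyl on an aromatic carbon, meta to a large group, gives a number 4 percentage points lower from compound 1 to compound 4 (within the scatter). This position of the shared core therefore accepts ethoxycarbonyl without a step beyond the scatter, something the earlier step, a change of configuration alone, could not show. Nothing known about these compounds bears on why this is so. As far as these compounds go, whether an amine, a carboxylic acid or a longer alkyl chain on this aromatic carbon would also stay within the scatter remains open.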